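A few compounds are considered here, and "the series" means these few. Any claim that something is new, unique, unknown or untested is made for them only; others in the source may bear on it.

Values measured so far in a functional assay on K562/A02 cells (Homo sapiens) for antiproliferative activity, read by MTT assay; on this read-out higher numbers stand for weaker inhibition and lower numbers for stronger inhibition

- Compound 1 (`O=C(CCCCCNC(=S)NN=C(c1ccccn1)c1ccccn1)NO`) gives 2180 nM
- Compound 2 (`Cc1ccc(/C(=N/NC(=S)NCCCCCC(=O)NO)c2ccccc2)cc1`) gives 3150 nM
- Compound 3 (`COc1cccc(/C(C)=N/NC(=S)NCCCCCC(=O)NO)c1`) gives 1890 nM

Repeated measurements of this kind scatter from run to run, so a small gap between two numbers need not mean a real difference. Compound 3 is the starting point here, and its value lies within that scatter of the values of both compound 1 and compound 2. On these numbers, compound 3 cannot be told apart from either of them.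

Compound 4 (`C/C(=N\NC(=S)NCCCCCC(=O)NO)c1cccc(C)c1`) has not yet been measured in this assay. Its structure follows from compound 3 by one small edit, with methyl in place of methoxy on an aromatic carbon, meta to a large group (methyl in place of methoxy on an aromatic carbon). In other words, 3-methoxyphenyl becomes 3-methylphenyl.

Within the data shown here, no two measured compounds differ in only one place, so no direct precedent exists for this edit. Among the measured compounds shown here, the only guide is the overall spread: compound 1 at 2180 nM and compound 2 at 3150 nM carry other groups than compound 3, yet stay within the scatter of it. The expected 1.2-fold higher number from compound 3 to compound 4 (0.07 log units; within the scatter) is therefore no larger than the scatter, with no firm direction. The estimate for compound 4 is 2200 nM (expected range 1000 nM to 4800 nM).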

Compound 4, half-maximal inhibitory concentration: 3570 nM
Estimate against measurement, compound 4: 1.6-fold (0.21 log units) below, and the stated range covers the measured number.
By their numbers in this assay, from the lowest: compounds 3, 1, 2 and 4 (each within the scatter of the next).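

In this assay, among these compounds, the first comparison that isolates a single change is methyl in place of methoxy on an aromatic carbon, meta to a large group, which gives a 1.9-fold higher number from compound 3 to compound 4 (0.28 log units; within the scatter) and so cannot be told apart from run-to-run variation. At this position, then, taking away the oxygen of the methoxy, and with it the hydrogen-bond acceptor that group carries, produces no difference that these numbers can establish as real, although a small true difference could still be hidden within the scatter. No separate measurement bears on this result, so nothing here can say what either group does at this position.

Methoxy and methyl are both small groups, so it remains open whether a group of a different kind at this position, such as an amine, a carboxylic acid or a longer chain like butoxy, would move the number beyond the scatter. It is also open how either of these compounds compares with the plain phenyl analogue carrying only hydrogen at this carbon, which would show whether the position needs any group at all.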